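This account rests on a few compounds, and the source may have more. Where it says the series, first, only, none or still open, it means among the compounds named here.

Measured so far in a functional assay on SK-OV-3 cells (Homo sapiens) for antiproliferative activity, read by MTT assay, with a stated time of 24 h (on this read-out higher numbers stand for weaker inhibition and lower numbers for stronger inhibition), each value a limit and not a number:
- compound 1 `COc1ccc(C(=O)/C=C/c2cccc(F)c2)c2c1C=CC(C)(C)O2`: > 10000 nM
- compound 2 `COc1ccc(C(=O)/C=C/c2ccccc2)c2c1C=CC(C)(C)O2`: > 10000 nM
- compound 3 `COc1ccc(/C=C/C(=O)c2ccc(OC)c3c2OC(C)(C)C=C3)cn1`: > 10000 nM

Compound 3 is known only as > 10000 nM, which is a limit. It has no number of its own and shares its place with the other two compounds: the limit of > 10000 nM in this assay, at which 3 of the 3 values shown sit.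

The next compound is compound 4 `COc1ccc(C(=O)/C=C/c2ccccn2)c2c1C=CC(C)(C)O2`, not yet measured. It carries pyridin-2-yl in place of 6-methoxypyridin-3-yl on a double-bonded chain carbon bound to a double-bonded chain carbon.

The nearest evidence is at that same place: a step that the two limits leave unreadable from compound 2 to compound 3, and also a step that the two limits leave unreadable from compound 1 to compound 3. The remaining measured step, a step that the two limits leave unreadable from compound 1 to compound 2, is a change on an aromatic carbon of the same group. None of the three gives a size to carry over.

With compound 1, compound 2 and compound 3 all held at the limit of > 10000 nM in this assay, at which 3 of the 3 values shown sit, no step beyond the scatter is expected in this assay, and no direction can be assigned. The expected step is a step that the limit leaves unreadable from compound 3 to compound 4. Compound 4 is estimated at 15000 nM, with an expected range of 5000 nM to 50000 nM, and the likeliest report is again only a limit.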

Compound 4, half-maximal inhibitory concentration: 8390 nM
Compound 4: the middle estimate sits 1.8-fold (0.25 log units) above what was measured; the measured number falls inside the stated range.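

In this assay, going by these compounds alone, compound 4 gives 8390 nM, the first value that is a number and not a limit, so pyridin-2-yl makes this place on a double-bonded chain carbon bound to a double-bonded chain carbon readable for the first time. Three steps can now be given, each only as a floor: an at least 1.1-fold lower number from compound 3 to compound 4 (0.07 log units; that floor lies within the scatter), an at least 1.1-fold lower number from compound 2 to compound 4 (0.07 log units; that floor lies within the scatter) and an at least 1.1-fold lower number from compound 1 to compound 4 (0.07 log units; that floor lies within the scatter). The steps among compound 1, compound 2 and compound 3 still cannot be read, each of the three being known only as a limit: the limit of > 10000 nM in this assay, at which 3 of the 4 values shown sit.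

With floors of this size, the compounds shown do not settle whether pyridin-2-yl truly differs from phenyl, 3-fluorophenyl or 6-methoxypyridin-3-yl at this place, since the true size of each step could be anywhere from the floor upward. Also open, going by these compounds, is what pyridin-3-yl without the methoxy group, or a phenyl carrying a dimethylamino group, would give at the same place in this assay, and whether the ring nitrogen or the group as a whole governs the result.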